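The source may hold more compounds than are shown below. What is called first, only, known or untested is meant among the compounds shown, and "the series" means these compounds.

Measured so far:
Compound 1, `CCC(COc1cccc(Br)c1)OC(=O)NCc1ccccc1`, gives > 100000 nM in an assay for inhibition of zeta-carotene desaturase, chloroplastic/chromoplastic (Capsicum annuum), using a Dixon plot, with a stated time of 8 h; a lower number here means a stronger inhibitor, a higher number a weaker inhibitor.
Compound 2, `CCOC(=O)c1cccc(OCC(CC)OC(=O)NCc2ccccc2)c1`, gives > 100000 nM in this assay.

Compound 1 stands only at a limit in this assay: its value is a limit of the assay. The same holds for compound 2. Within the data shown here, the single measured step, a step that the two limits leave unreadable from compound 1 to compound 2, cannot be sized because of the limit of > 100000 nM in this assay, at which 2 of the 2 values shown sit. Compound 3, `CCC(COc1cc(Cl)ccc1Cl)OC(=O)NCc1ccccc1`, differs from compound 1 by 2,5-dichlorophenyl in place of 3-bromophenyl on an oxygen on a saturated carbon. Among the measured compounds shown here, no measured step bears on this change, so nothing beyond the scatter can be expected in either direction. Compound 3 is estimated at 150000 nM in this assay, with a range from 50000 nM to 500000 nM. This estimate means an expected step that the limit leaves unreadable from compound 1 to compound 3.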

Compound 3, half-maximal inhibitory concentration: > 100000 nM
Compound 3: only a limit was reported; the forecaster's own chance of this, stated with the estimate: 85%; the middle value is on the limit's open side.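

No step can be read from compound 1 to compound 3, as both stand only at a limit in this assay: the limit of > 100000 nM in this assay, at which 3 of the 3 values shown sit.
The compounds shown leave open whether any substituent on this aromatic ring gives a readable value in this assay.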